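Swapping methyl for dimethylamino on two related cores

A few compounds are considered here, and "the series" means these few. Any claim that something is new, unique, unknown or untested is made for them only; others in the source may bear on it.

Compound 1 `Cc1ccc(/C=C2\S/C(=N\c3csc(-c4ccc(Cl)cc4)c3)NC2=O)cc1` and compound 2 `CN(C)c1ccc(/C=C2\S/C(=N\c3csc(-c4ccc(Cl)cc4)c3)NC2=O)cc1` share one core, while compound 3 `Cc1ccc(N2C(=O)CS/C2=N\c2csc(-c3ccc(Cl)cc3)c2)cc1` and compound 4 `CN(C)c1ccc(N2C(=O)CS/C2=N\c2csc(-c3ccc(Cl)cc3)c2)cc1` share another; the difference between the two cores is not broken down here. In a functional assay on HT-29 cells (Homo sapiens) for cytotoxicity, read by MTT assay, with a stated time of 72 h (a lower number here means a stronger inhibitor, a higher number a weaker inhibitor), compound 1 gives 6400 nM, and compound 2 gives 1500 nM. These two differ in a single place, (dimethylamino in place of methyl on an aromatic carbon), and that change made a 4.3-fold lower number from compound 1 to compound 2 (0.63 log units; beyond the scatter). Compound 3 gives 28900 nM, the highest number of the three measured compounds. Compound 4 carries the same change on the second core, (dimethylamino in place of methyl on an aromatic carbon). For the measured compounds named here, a step of similar size is expected for compound 4, a 3.9-fold lower number from compound 3 to compound 4 (0.59 log units; beyond the scatter), because the same change gave a 4.3-fold lower number from compound 1 to compound 2 (0.63 log units; beyond the scatter), though only one earlier example supports this. Compound 4 is therefore estimated at 7500 nM, with a likely range from 2500 nM to 25000 nM.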

Compound 4, half-maximal inhibitory concentration: 29200 nM
Compound 4: middle estimate off by 3.9-fold (0.59 log units), on the low side, outside the stated range (above it).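

In this assay, putting dimethylamino in place of methyl on the second core gave a 1.0-fold higher number from compound 3 to compound 4 (0.00 log units; within the scatter), so the gain seen on the first core does not reappear on this one. The effect of this swap therefore depends on the core it is made on, and it cannot simply be carried from one core to the other in this series: the same change on two cores in this assay, a 4.3-fold lower number (0.63 log units; beyond the scatter) from compound 1 to compound 2 and a 1.0-fold higher number (0.00 log units; within the scatter) from compound 3 to compound 4, 4.3-fold (0.63 log units) apart, beyond the scatter of two such steps. For the compounds shown here, with only two cores compared, this does not show which feature of the cores is responsible, or how the swap would behave on a third core.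

From the compounds shown here alone, it remains open whether other groups in place of the methyl, such as methoxy or a carboxylic acid, would also give different results on the two cores.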